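Swapping an Isopropyl for a Double Bond

The source may report more compounds than this note shows. Statements on the series, on what has been measured and on what is new or still open speak of the compounds shown alone.

Measured so far:
compound 1, `CCOc1ccc(-c2c(C#N)c(N)nc(SCc3ccn[nH]3)c2C#N)cc1`, gives 18%
compound 2, `N#Cc1c(N)nc(SCC(=O)NCO)c(C#N)c1-c1ccc(OCC2CC2)cc1`, gives 8%
compound 3, `CC(C)COc1ccc(-c2c(C#N)c(N)nc(SCC(N)=O)c2C#N)cc1`, gives 9%

These three share one core and differ in the groups hanging from it. In an assay on CHO cells for displacement of a labelled ligand from adenosine receptor A3 (Homo sapiens), read by scintillation counting, with a stated time of 120 min, tested at 1 uM (a higher number here means more inhibition at the concentration tested (going by the name of the read-out), a lower number less inhibition), compound 3 stands second of the three numbers, yet its gap to compound 2 and its gap to compound 1 both lie within the usual scatter, so the three are not separated by this measurement.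

Compound 4, `C=C(C)COc1ccc(-c2c(C#N)c(N)nc(SCC(N)=O)c2C#N)cc1`, has not been measured. Compared with compound 3 it carries one change: 1-methylethenyl in place of isopropyl on a saturated chain carbon bound to an oxygen on an aromatic ring. The exchanged groups are of the same size and neither brings a donor or an acceptor; only a double bond outside aromatic rings is added.

For the measured compounds named here, no pair of measured compounds that differ in one place is available, so no step of this kind has been seen. The expectation for compound 4 is a step from compound 3 that stays within the scatter, with no clear direction, so a number 1 percentage points higher from compound 3 to compound 4 (within the scatter) is estimated as essentially flat. Compound 4 is therefore expected to give about 10%, between 2% and 22%.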

Compound 4, a percentage reported as inhibition, at one concentration (the size of the read-out at that concentration, not a potency): 4%
Compound 4: the middle estimate sits 6 percentage points above what was measured, and the stated range covers the measured number.
By their numbers in this assay, from the lowest: compounds 4, 2, 3 and 1 (each within the scatter of the next, the first and the last beyond it).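

For the compounds shown here, this is the first step seen between compounds that differ in one place: in this assay, 1-methylethenyl in place of isopropyl on a saturated chain carbon bound to an oxygen on an aromatic ring gives a number 5 percentage points lower from compound 3 to compound 4 (within the scatter). At this place, then, adding a double bond outside aromatic rings while keeping the same number of heavy atoms does not separate the two compounds in this measurement. No measurement shown here offers an explanation for this step.

From the compounds shown here alone, whether a longer chain, a cyclopentyl ring or an amine on this carbon would produce a step beyond the scatter stays open. Going by these compounds alone, the read-out also comes from a single concentration, so it gives no potency for either compound.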